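Working notes: a chain change from compound 2

The source may hold more compounds than are shown below. What is called first, only, known or untested is meant among the compounds shown, and "the series" means these compounds.

Measured in a functional assay on NCI-H460 cells (Homo sapiens) for antiproliferative activity, read by MTT assay, with a stated time of 48 h; a higher number here means a weaker inhibitor, a lower number a stronger inhibitor:
compound 1 `CCCCCCC1(O)C(=O)Nc2ccc(Nc3ccc(OC)cc3)cc21`: > 100000 nM
compound 2 `CC(C)CCC1(O)C(=O)Nc2ccc(Nc3ccc(Cl)cc3)cc21`: 25000 nM

The reading for compound 1, > 100000 nM, is a limit of the assay and not a number. For the measured compounds named here, compound 2, at 25000 nM, therefore gives the only actual number so far, and it is the sole anchor for what follows.

Compound 3 `CCCCCCC1(O)C(=O)Nc2ccc(Nc3ccc(Cl)cc3)cc21` has not yet been measured. It carries butyl in place of isopropyl on a saturated chain carbon, two bonds along the chain from a saturated ring carbon. The same difference can be read as isopentyl to hexyl.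

Going by the values given here, no measured pair isolates a change of this kind, so its size has no direct precedent. The change is confined to the end of the chain, and the expectation starts from compound 2 at 25000 nM, with no step beyond the scatter and no firm direction. In this assay the expected result is a 1.1-fold lower number from compound 2 to compound 3 (0.06 log units; within the scatter).

For compound 3 the estimated value is 22000 nM, with an expected range of 9000 nM to 60000 nM.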

Compound 3, half-maximal inhibitory concentration: 30300 nM
Compound 3: the middle estimate sits 1.4-fold (0.14 log units) below what was measured; the range from low to high includes it.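

In this assay, butyl in place of isopropyl on a saturated chain carbon, two bonds along the chain from a saturated ring carbon, gives a 1.2-fold higher number from compound 2 to compound 3 (0.08 log units; within the scatter), so this first direct test of the chain shows that isopentyl and hexyl cannot be told apart at this position on the chloro-bearing compounds. For the compounds shown here, with the hexyl chain held constant, chloro in place of methoxy on an aromatic carbon gives an at least 3.3-fold lower number from compound 1 to compound 3 (0.51 log units; beyond the scatter), which is the first step beyond the scatter and places the readable change at the aromatic substituent rather than at the chain end. Compound 1 reads > 100000 nM, which is a limit of the assay and not a number, so the full size of that step stays unknown: the limit of > 100000 nM in this assay, at which 1 of the 3 values shown sits.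

The compounds shown leave open whether a much shorter chain such as ethyl, or a chain ending in an amine or a carboxylic acid, would move the number away from the level of compound 2 and compound 3. As far as these compounds go, it also remains open whether fluoro, bromo or trifluoromethyl in place of chloro on the aromatic carbon would give a lower number.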